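The source may hold more compounds than are shown below. What is called first, only, known or untested is meant among the compounds shown, and "the series" means these compounds.

Three compounds share one core and differ only in the group on a carbonyl carbon attached to an amide-type nitrogen in a ring. In an ADME assay on LLC-PK1 cells (Sus scrofa) for permeability (on this read-out lower numbers stand for lower permeability and higher numbers for higher permeability), compound 3 `CCn1c(-c2ccc(C(F)(F)F)nc2)nc2c(O[C@H]3CCN(C(=O)N4CC(OC)C4)C3)ncnc21` gives 33 10^-6 cm/s, the second highest of the three numbers. Compound 1 `CCn1c(-c2ccc(C(F)(F)F)nc2)nc2c(O[C@H]3CCN(C(=O)[C@H]4C[C@@H](OC)C4)C3)ncnc21` gives 35 10^-6 cm/s, and compound 2 `CCn1c(-c2ccc(C(F)(F)F)nc2)nc2c(O[C@H]3CCN(C(=O)C4CCOC4)C3)ncnc21` gives 27 10^-6 cm/s. The steps are all small: a 1.1-fold lower number from compound 1 to compound 3 (0.03 log units; within the scatter), a 1.2-fold higher number from compound 2 to compound 3 (0.09 log units; within the scatter) and a 1.3-fold lower number from compound 1 to compound 2 (0.11 log units; within the scatter). Compound 4 `CCn1c(-c2ccc(C(F)(F)F)nc2)nc2c(O[C@H]3CCN(C(=O)c4cocn4)C3)ncnc21` carries a further swap at the same carbonyl carbon: 1,3-oxazol-4-yl in place of 3-methoxyazetidin-1-yl on a carbonyl carbon. Since earlier swaps at this position moved nothing beyond the scatter, compound 4 is expected to show a 1.1-fold lower number from compound 3 to compound 4 (0.04 log units; within the scatter) in this assay, that is no step beyond the scatter. The estimate for compound 4 is therefore 30 10^-6 cm/s, with a range from 17 10^-6 cm/s to 50 10^-6 cm/s.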

Compound 4, apparent permeability in the LLC-PK1 assay: 29 10^-6 cm/s
Beside the measured number, compound 4's estimate is 1.0-fold (0.01 log units) above it; the measured number falls inside the stated range.
By their numbers in the LLC-PK1 assay, from the lowest: compounds 2, 4, 3 and 1 (each within the scatter of the next).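

Among the compounds shown here, in the LLC-PK1 assay compound 4 gives 29 10^-6 cm/s with an aromatic ring, 1,3-oxazol-4-yl, on this carbonyl carbon, where the earlier compounds carried non-aromatic rings, and this leaves the number within the scatter of all three (a 1.1-fold lower number from compound 3 to compound 4 (0.06 log units; within the scatter); a 1.1-fold higher number from compound 2 to compound 4 (0.03 log units; within the scatter); a 1.2-fold lower number from compound 1 to compound 4 (0.08 log units; within the scatter)). In a physicochemical assay for lipophilicity, read by HPLC (on this read-out higher numbers stand for higher lipophilicity and lower numbers for lower lipophilicity), compound 3 gives 2.1 and compound 4 gives 2 and the same swap also stays within the scatter (a number 0.10 log units lower from compound 3 to compound 4 (within the scatter)). Nothing available here explains why the numbers stay so close. Still open, as far as these compounds go, is whether a dimethylamino group or a carboxylic acid at this carbonyl carbon would also stay within the scatter.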